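A few compounds are considered here, and "the series" means these few. Any claim that something is new, unique, unknown or untested is made for them only; others in the source may bear on it.

The measured compounds in a functional assay on A-375 cells (Homo sapiens) for antiproliferative activity, read by MTT assay, with a stated time of 24 h; on this read-out lower numbers stand for stronger inhibition and higher numbers for weaker inhibition:

compound 1, `COc1cc(OC)c(-c2coc3cc(OCC=C(C)C)ccc3c2=O)cc1OC`, gives 1580 nM
compound 2, `COc1cc(OC)c(-c2coc3cc(OCc4ccccc4)ccc3c2=O)cc1OC`, gives 1640 nM
compound 3, `COc1cc(OC)c(-c2coc3cc(OCc4ccc(C#N)cc4)ccc3c2=O)cc1OC`, gives 1550 nM

Compound 3 has the lowest of the three numbers, yet it is not set apart: the step of a 1.0-fold lower number from compound 1 to compound 3 (0.01 log units; within the scatter) and the step of a 1.1-fold lower number from compound 2 to compound 3 (0.02 log units; within the scatter) both lie within the scatter, so the three compounds cannot be ordered on this read-out.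

Compound 4, `COc1cc(OC)c(-c2coc3cc(OCc4cccc(Br)c4)ccc3c2=O)cc1OC`, is the next compound in this series. Its difference from compound 3 is 3-bromophenyl in place of 4-cyanophenyl on a saturated chain carbon bound to an oxygen on an aromatic ring.

Among the compounds with values here, three measured steps bear on this change, all at the same place on the shared core. The step of a 1.0-fold higher number from compound 1 to compound 2 (0.02 log units; within the scatter) exchanged an open chain for an aromatic ring; the step of a 1.0-fold lower number from compound 1 to compound 3 (0.01 log units; within the scatter) did the same with a ring bearing a nitrile; and the step of a 1.1-fold lower number from compound 2 to compound 3 (0.02 log units; within the scatter) added the nitrile to the ring. Every one of them stayed within the scatter. Swapping one substituted aromatic ring for another at this position is therefore expected to give no step beyond the scatter in this assay, and the expected step of a 1.0-fold higher number from compound 3 to compound 4 (0.01 log units; within the scatter) reflects that.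

Compound 4 is thus estimated at 1600 nM, with a range from 800 nM to 3200 nM.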

Compound 4, half-maximal inhibitory concentration: 1120 nM
For compound 4 the middle estimate is 1.4-fold (0.15 log units) above the measured one; the range from low to high includes it.
By their numbers in this assay, from the lowest: compounds 4, 3, 1 and 2 (each within the scatter of the next).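

The exchange of 4-cyanophenyl for 3-bromophenyl on the saturated chain carbon bound to an oxygen on an aromatic ring gives, in this assay, a 1.4-fold lower number from compound 3 to compound 4 (0.14 log units; within the scatter) and so stays within the scatter, as do the two other steps that reach compound 4, namely a 1.5-fold lower number from compound 2 to compound 4 (0.17 log units; within the scatter) and a 1.4-fold lower number from compound 1 to compound 4 (0.15 log units; within the scatter) at this same position. These steps are larger in size than any seen among the first three compounds, yet none separates compound 4 from the others, so a bromo group now joins the nitrile, the unsubstituted phenyl and the 2-methylprop-1-en-1-yl group among the changes here that produce no step beyond the scatter. Nothing measured here accounts for how closely these numbers lie together.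

From the compounds shown here alone, whether an amine or a carboxylic acid on this aromatic ring, or a longer chain in place of the benzyl group, would give a step beyond the scatter remains open. Also open, going by these compounds, is whether 4-bromophenyl would read any differently from 3-bromophenyl in this position.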